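The source may hold more compounds than are shown below. What is called first, only, known or untested is meant among the compounds shown, and "the series" means these compounds.

Three compounds share one core and differ only in the group carried on a saturated ring carbon. Compound 1 `O=C(C(Nc1ccccc1F)c1ccc(C(F)(F)F)cc1)N1CCCC1c1ccccc1Cl` gives 11 nM in an assay on HEK293 cells for antagonist activity at transient receptor potential M8 protein (Canis lupus familiaris), read by fluorescence and calcium flux, with a stated time of 5 min; a lower number here means a stronger inhibitor, a higher number a weaker inhibitor. Compound 2 `O=C(C(Nc1ccccc1F)c1ccc(C(F)(F)F)cc1)N1CCCC1c1ccccn1` gives 25 nM in this assay, and compound 3 `O=C(C(Nc1ccccc1F)c1ccc(C(F)(F)F)cc1)N1CCCC1c1ccncc1` gives 19 nM in this assay. The three steps among them are all small: a 2.3-fold higher number from compound 1 to compound 2 (0.36 log units; beyond the scatter), a 1.7-fold higher number from compound 1 to compound 3 (0.24 log units; within the scatter) and a 1.3-fold lower number from compound 2 to compound 3 (0.12 log units; within the scatter). Compound 3 thus sits second highest of the three numbers, nearest to compound 2 and furthest from compound 1, both within the scatter.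

Compound 4 `O=C(O)c1cccc(C2CCCN2C(=O)C(Nc2ccccc2F)c2ccc(C(F)(F)F)cc2)c1` carries the change (3-carboxyphenyl in place of pyridin-4-yl on a saturated ring carbon). All three measured steps bear on it in so far as each exchanges one aromatic group for another on this same carbon, and none of them moved the number by more than a modest amount. Among the measured compounds shown here, none of them, however, brings in a carboxyphenyl group, so the measured steps give no direct precedent for this change. The author therefore expects a step of about a 1.8-fold higher number from compound 3 to compound 4 (0.27 log units; within the scatter) in this assay, with a wider range than the measured steps would suggest. For compound 4 the estimate in this assay is 35 nM, between 10 nM and 150 nM.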

Compound 4, half-maximal inhibitory concentration: 40 nM
The estimate for compound 4 lay 1.1-fold (0.06 log units) below the measured number; measured number inside the range.
By their numbers in this assay, from the lowest: compounds 1, 3, 2 and 4 (each within the scatter of the next, the first and the last beyond it).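

In this assay, the saturated ring carbon next to the ring nitrogen accepts 3-carboxyphenyl, which has more heavy atoms than pyridin-4-yl and brings a hydrogen-bond donor that pyridin-4-yl lacks, at the cost of only a modest step: a 2.1-fold higher number from compound 3 to compound 4 (0.32 log units; beyond the scatter). Measured against pyridin-2-yl, the same exchange stays inside the usual scatter, with a 1.6-fold higher number from compound 2 to compound 4 (0.20 log units; within the scatter), while against 2-chlorophenyl it gives the largest step in this small set, though still a modest one, with a 3.6-fold higher number from compound 1 to compound 4 (0.56 log units; beyond the scatter). The earlier compounds showed tolerance only among aromatic rings without a carboxylic acid, and the numbers now extend that tolerance to this group, but no accompanying measurement explains these steps.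

Going by these compounds, how a plain phenyl group would stand at this carbon remains open, so the step to compound 4 cannot be divided between the change of ring and the carboxylic acid it carries. Also open, on these data alone, is whether a methyl ester, a primary amide or an aminomethyl group in place of that carboxylic acid would keep the number in the same range.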